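Aryl variation at the pyridine core: toward compound 4

The source may hold more compounds than are shown below. What is called first, only, known or untested is meant among the compounds shown, and "the series" means these compounds.

The series shares one core and varies the aryl substituent next to the nitrile. Compound 1 `CCOc1nc(-c2cc3ccccc3o2)cc(-c2cccc3ccccc23)c1C#N` carries a naphthalen-1-yl group and gives 344000 nM in a functional assay on aorta (strain Wistar) for inhibition, with Thoracic aorta (Rattus norvegicus) as the target; on this read-out lower numbers stand for stronger inhibition and higher numbers for weaker inhibition. Compound 2 `CCOc1nc(-c2cc3ccccc3o2)cc(-c2ccc(Cl)cc2)c1C#N` carries a 4-chlorophenyl group and gives 221000 nM. Compound 3 `CCOc1nc(-c2cc3ccccc3o2)cc(-c2ccc(Cl)cc2Cl)c1C#N` carries a 2,4-dichlorophenyl group and gives 442000 nM, the highest of the three numbers, though its steps to both others lie within the scatter: a 1.3-fold higher number from compound 1 to compound 3 (0.11 log units; within the scatter) and a 2.0-fold higher number from compound 2 to compound 3 (0.30 log units; within the scatter). The third step, a 1.6-fold lower number from compound 1 to compound 2 (0.19 log units; within the scatter), is likewise within the scatter, so across these three aryl groups no change beyond the noise has been seen.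

Compound 4 `CCOc1nc(-c2cc3ccccc3o2)cc(-c2ccc(Br)cc2)c1C#N` has not been measured. Relative to compound 3 the change is 4-bromophenyl in place of 2,4-dichlorophenyl on an aromatic carbon. The step from compound 2 to compound 3 bears on it most directly, as the extra chloro leaves again and the remaining halogen is exchanged; that step was within the scatter, as were the other two. The expected step is therefore a 1.8-fold lower number from compound 3 to compound 4 (0.25 log units; within the scatter), a lower number but not beyond the scatter, with compound 2 as the closest reference at 221000 nM. For compound 4 the estimate in this assay is 250000 nM, with a range from 120000 nM to 520000 nM.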

Compound 4, half-maximal inhibitory concentration: 227000 nM
Compound 4: the middle estimate sits 1.1-fold (0.04 log units) above what was measured, within the range that was stated.
By their numbers in this assay, from the lowest: compounds 2, 4, 1 and 3 (each within the scatter of the next).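

In this assay, the exchange of 4-chlorophenyl for 4-bromophenyl, on the carbon ortho to a cyano group and opposite the ring nitrogen, gives a 1.0-fold higher number from compound 2 to compound 4 (0.01 log units; within the scatter). Among the compounds shown here, this is the first exchange of one halogen for another seen at this position and the smallest step in the set, so the two compounds cannot be told apart on this read-out. The other two comparisons, a 1.9-fold lower number from compound 3 to compound 4 (0.29 log units; within the scatter) and a 1.5-fold lower number from compound 1 to compound 4 (0.18 log units; within the scatter), also stay within the scatter, which extends the flat picture at this position to a fourth aryl group; no information available here accounts for it.

Still open, on these data alone, is whether any group at this position can move the number beyond the scatter, for instance a phenyl ring carrying an amine or a carboxylic acid rather than a halogen. The compounds shown also leave open how much the other positions of the shared core contribute, since the ethoxy group and the 1-benzofuran-2-yl group stay the same throughout, and a longer chain in place of the ethoxy group would test the first of these.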